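Pyridin-4-yl in Place of a Dichlorothienyl Group

The source may hold more compounds than are shown below. What is called first, only, known or untested is meant among the compounds shown, and "the series" means these compounds.

Measured compounds:
- compound 1, `COC(=O)C1=C(C)NC(C)=C(C(=O)OC)C1c1c(-c2c(Cl)csc2Cl)nc2sc(C)cn12`, 3230 nM
- compound 2, `COC(=O)C1=C(C)NC(C)=C(C(=O)OC)C1c1c(-c2ccccn2)nc2sccn12`, 2570 nM

Of the compounds shown here, two have been measured in a functional assay on ileum (Cavia porcellus) for inhibition; on this read-out lower numbers stand for stronger inhibition and higher numbers for weaker inhibition. Compound 1 gives 3230 nM in this assay, and compound 2 gives 2570 nM. The two values lie within the usual scatter of each other, so neither compound can be placed ahead of the other; compound 1 simply sits among weakly inhibiting numbers.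

Compound 3, `COC(=O)C1=C(C)NC(C)=C(C(=O)OC)C1c1c(-c2ccncc2)nc2sc(C)cn12`, has not yet been measured. Relative to compound 1 the change is a group of 6 heavy atoms (5 carbon, 1 nitrogen; one six-membered aromatic ring with 1 hetero atom) in place of a group of 7 heavy atoms (4 carbon, 1 sulfur, 2 chlorine; one five-membered aromatic ring with 1 hetero atom), on an aromatic carbon. Going by the values given here, no step between measured compounds isolates this exchange, so nothing measured here shows how it acts. The step from compound 1 to compound 3 is therefore expected to be a 1.1-fold lower number from compound 1 to compound 3 (0.03 log units; within the scatter), that is, no change beyond the scatter. Compound 3 is estimated at 3000 nM in this assay, with a range from 1000 nM to 9000 nM.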

Compound 3, half-maximal inhibitory concentration: 9690 nM
Compound 3: middle estimate off by 3.2-fold (0.51 log units), on the low side, and the stated range ends below it.
By their numbers in this assay, from the lowest: compounds 2 and 1 (each within the scatter of the next); then compound 3.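

In this assay, the step from the group with the chlorine-bearing five-membered ring to pyridin-4-yl gives a 3.0-fold higher number from compound 1 to compound 3 (0.48 log units; beyond the scatter), so this aromatic carbon of the core does not accept every aromatic ring alike. Going by these compounds alone, this is the first exchange at the position that can be read on its own, and it goes toward weaker inhibition, although the starting point in compound 1 was already weak. No available evidence bears on why the number rises with this change.

Compound 2 carries a pyridin-2-yl group but differs from compound 3 in more than one place, so the two cannot show whether the place of the ring nitrogen matters. From the compounds shown here alone, whether a phenyl, a chlorophenyl or a pyridin-3-yl group would stay near compound 1 or fall with compound 3 remains open.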